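The source may report more compounds than this note shows. Statements on the series, on what has been measured and on what is new or still open speak of the compounds shown alone.

Of the compounds shown here, three sharing one core have been measured so far. Compound 1 `N#CC1=C(N)N(c2ccc(S(N)(=O)=O)cc2)C2=C(C(=O)CCC2)C1c1ccc(Cl)cc1Cl` carries a free amino group, and in a functional assay on Ehrlich cells (Mus musculus) for cytotoxicity, read by trypan blue exclusion, with a stated time of 2 h, tested at 10 ug/mL (a higher number here means a stronger effect of the compound at the concentration tested, a lower number a weaker effect), compound 1 gives 40%. Compound 2 `N#CC1=C(NC(=O)CCC(=O)O)N(c2ccc(S(N)(=O)=O)cc2)C2=C(C(=O)CCC2)C1c1ccc(Cl)cc1Cl` carries a (2-carboxyethyl)carbonyl group on that amine nitrogen, and in this assay compound 2 gives 20%. Compound 3 `N#CC1=C(NS(=O)(=O)c2ccc([N+](=O)[O-])cc2)N(c2ccc(S(N)(=O)=O)cc2)C2=C(C(=O)CCC2)C1c1ccc(Cl)cc1Cl` carries a (4-nitrophenyl)sulfonyl group there, and in this assay compound 3 gives 50%. Among these three numbers compound 1 stands second highest: the gap to compound 3 is a number 10 percentage points higher from compound 1 to compound 3 (within the scatter), which does not exceed the scatter, while the gap to compound 2 is a number 20 percentage points lower from compound 1 to compound 2 (beyond the scatter), which does.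

Compound 4 `N#CC1=C(NS(=O)(=O)c2ccc(Br)cc2)N(c2ccc(S(N)(=O)=O)cc2)C2=C(C(=O)CCC2)C1c1ccc(Cl)cc1Cl` has not yet been measured. Compared with compound 1 the change is (4-bromophenyl)sulfonyl in place of hydrogen on an amine nitrogen. Within the data shown here, the step that bears most directly on this is the one from compound 1 to compound 3, where another sulfonyl group entered at the same nitrogen and gave a number 10 percentage points higher from compound 1 to compound 3 (within the scatter). The comparison between compound 2 and compound 3, a number 30 percentage points higher from compound 2 to compound 3 (beyond the scatter), shows that a sulfonyl group on this nitrogen fared better than the carbonyl chain. For compound 4 a step of about a number 10 percentage points higher from compound 1 to compound 4 (within the scatter) is therefore expected, not clearly beyond the scatter. Compound 4 is estimated at 50%, plausibly between 35% and 65%.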

Compound 4, a percentage reported as activity, at one concentration (the size of the read-out at that concentration, not a potency): 90%
Compound 4: middle estimate off by 40 percentage points, on the low side, and the stated range ends below it.
By their numbers in this assay, from the lowest: compound 2; then compounds 1 and 3 (each within the scatter of the next); then compound 4.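

The sulfonyl group on this amine nitrogen can do much more than compound 3 suggested, since the (4-bromophenyl)sulfonyl group gives a number 50 percentage points higher from compound 1 to compound 4 (beyond the scatter) in this assay, whereas the step to compound 3 stayed within the scatter. The sulfonyl link alone therefore does not set the result, as exchanging only the group on the aromatic ring, bromo in place of nitro, gives a number 40 percentage points higher from compound 3 to compound 4 (beyond the scatter). The choice of group on this nitrogen also spans a wide range in this small set: (4-bromophenyl)sulfonyl in place of (2-carboxyethyl)carbonyl gives a number 70 percentage points higher from compound 2 to compound 4 (beyond the scatter).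

Nothing available here explains why bromo and nitro on the same ring give such different numbers. The compounds shown leave open whether the rise is specific to bromo or would also appear with chloro, methyl or methoxy on that ring, or with a plain phenylsulfonyl group, and whether a bromophenyl ring joined through a carbonyl instead of a sulfonyl would give a similar number.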